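A few compounds are considered here, and "the series" means these few. Any claim that something is new, unique, unknown or untested is made for them only; others in the source may bear on it.

Measured in a functional assay on A549 cells (Homo sapiens) for antiproliferative activity, read by XTT assay, with a stated time of 72 h; a higher number here means a weaker inhibitor, a lower number a stronger inhibitor:
- compound 1 `C=C(C)CCC[C@]1(C)C2=CCC[C@](C)(CC(=O)c3ccoc3)[C@H]2CC[C@H]1C`: > 100000 nM
- compound 2 `CC(C)=CCC[C@]1(C)C2=CCC[C@](C)(CC(=O)c3ccoc3)[C@H]2CC[C@H]1C`: 91000 nM
- compound 3 `C=C(C)CC[C@]1(C)C2=CCC[C@](C)(C[C@@H](OC(C)=O)C3=CC(=O)OC3O)[C@H]2CC[C@H]1C`: 11100 nM

The result of compound 1 is a limit and not a number: the limit of > 100000 nM in this assay, at which 1 of the 3 values shown sits.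

Compound 4 `C=C(C)CCC[C@]1(C)C2=CCC[C@](C)(C[C@@H](O)c3ccoc3)[C@H]2CC[C@H]1C` keeps the core of compound 1 and changes one group: (furan-3-yl)(hydroxy)methyl in place of (furan-3-yl)carbonyl on a saturated chain carbon bound to a saturated ring carbon. In words, (furan-3-yl)(hydroxy)methyl stands in place of (furan-3-yl)carbonyl on a saturated chain carbon bound to a saturated ring carbon.

Going by the values given here, only one measured step compares two compounds that differ in one place, an at least 1.0-fold lower number from compound 1 to compound 2 (0.04 log units; that floor lies within the scatter). It concerns a different group, and it shows no change beyond the scatter. Among the compounds with values here, no measured step therefore touches the carbonyl directly. The value of compound 3, 11100 nM, shows only that lower numbers occur among these compounds. Compound 2, at 91000 nM, suggests that close relatives of compound 1 stay weak.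

A modest move towards a lower number in this assay is therefore expected, though a result at the limit remains quite possible. The expected size of the change is an at least 2.2-fold lower number from compound 1 to compound 4 (0.34 log units; beyond the scatter). For compound 4 the estimate is 45000 nM, with an expected range from 12000 nM to 100000 nM.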

Compound 4, half-maximal inhibitory concentration: 66000 nM
Compound 4: middle estimate off by 1.5-fold (0.17 log units), on the low side; measured number inside the range.
By their numbers in this assay, from the lowest: compound 3; then compounds 4 and 2 (each within the scatter of the next). At a limit, above all of these: compound 1.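

In this assay, putting (furan-3-yl)(hydroxy)methyl in place of (furan-3-yl)carbonyl on a saturated chain carbon bound to a saturated ring carbon gives an at least 1.5-fold lower number from compound 1 to compound 4 (0.18 log units; that floor lies within the scatter). Going by these compounds alone, this is the first measured step that touches this place, and the entering group differs from the leaving one by a hydrogen-bond donor and a defined stereocentre, yet compound 4, at 66000 nM, shows no change that can be told from the scatter. The step is only a floor, and its true size cannot be read, because the result of compound 1 is a limit and not a number: the limit of > 100000 nM in this assay, at which 1 of the 4 values shown sits.

On these data alone, what stays open is whether the opposite arrangement at the new stereocentre, or an amine or a methoxy group in place of the hydroxy group on this carbon, would bring a clearly lower number in this assay. As far as these compounds go, it is also open whether the same change would give a similar step on the chain of compound 2, whose value is a number and not a limit, so that a step from it could be read in full.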